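Replacing the amino group of compound 3 with a nitro group

A few compounds are considered here, and "the series" means these few. Any claim that something is new, unique, unknown or untested is made for them only; others in the source may bear on it.

Measured so far:
- Compound 1, `COc1ccc(/C=C(/F)c2cc(OC)c(OC)c(OC)c2)cc1O`: 100 nM
- Compound 2, `COc1ccc(/C(F)=C\c2cc(OC)c(OC)c(OC)c2)cc1N`: 5 nM
- Compound 3, `COc1ccc(/C(F)=C(/F)c2cc(OC)c(OC)c(OC)c2)cc1N`: 4.5 nM

The three compounds were tested in a functional assay on HT-29 cells (Homo sapiens) for cytotoxicity, read by sulforhodamine B assay, with a stated time of 72 h; on this read-out higher numbers stand for weaker inhibition and lower numbers for stronger inhibition. Compound 3 shows the lowest number of the three with 4.5 nM, but compound 2 gives 5 nM, and the gap between these two lies within the scatter of repeated measurements, so neither can be called the stronger one. Compound 1 stands much further away with 100 nM, a gap beyond the scatter.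

The next compound, compound 4, `COc1ccc(/C(F)=C(/F)c2cc(OC)c(OC)c(OC)c2)cc1[N+](=O)[O-]`, is not yet measured. It differs from compound 3 in one place: nitro in place of amino on an aromatic carbon. Going by the values given here, no measured pair here carries this same change, so nothing in the data says directly how this assay responds to it. A change from an amino group to a nitro group on the ring is therefore an open question. As a cautious expectation, compound 4 is estimated to show a moderate rise in its number, a step of a 5.6-fold higher number from compound 3 to compound 4 (0.74 log units; beyond the scatter) in this assay, meaning somewhat weaker inhibition than compound 3. The estimated value for compound 4 is 25 nM, with a range from 5 nM to 150 nM.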

Compound 4, half-maximal inhibitory concentration: 1310 nM
Beside the measured number, compound 4's estimate is 52-fold (1.72 log units) below it; the measured number lies above the stated range.
By their numbers in this assay, from the lowest: compounds 3 and 2 (each within the scatter of the next); then compound 1; then compound 4.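

In this assay the group on this aromatic carbon, ortho to a methoxy group, proves decisive: nitro in place of amino gives a 290-fold higher number from compound 3 to compound 4 (2.46 log units; beyond the scatter) and thus a large loss of inhibition from a change in one place. The earlier compounds shown here included no pair differing in one place, so they could not show that the shared core alone is not enough for a low number and that this position tolerates at least one replacement very poorly. This single pair cannot separate the differences between the two groups, since the change adds heavy atoms, including two oxygens, and also removes the hydrogen-bond donor, and no further data here bear on why the number rises.

On these data alone, it remains open whether a methylamino group, an acetamide or a carboxylic acid on this carbon would stay close to compound 3 or move towards compound 4. As far as these compounds go, it is also open whether nitro in place of amino would cost as much on compound 2, which carries one fluorine fewer than compound 3.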